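This account rests on a few compounds, and the source may have more. Where it says the series, first, only, none or still open, it means among the compounds named here.

Within the data shown here, in an ADME assay for permeability, using PAMPA, at pH 7.4 (on this read-out lower numbers stand for lower permeability and higher numbers for higher permeability), compound 2 `Cc1[nH]c2ccc(Br)cc2c(=O)c1Br` gives 95.3 10^-6 cm/s and holds the higher of the two numbers so far, while compound 1 `Cc1[nH]c2ccccc2c(=O)c1Br` gives 13.6 10^-6 cm/s on the same scale. The next compound to be tested is compound 3 (`Cc1[nH]c2ccc(F)cc2c(=O)c1Br`), which differs from compound 2 at a single place (fluoro in place of bromo on an aromatic carbon): fluoro in place of bromo on an aromatic carbon. Among the measured compounds shown here, only one measured step bears on this change. That step is a 7.0-fold higher number from compound 1 to compound 2 (0.85 log units; beyond the scatter) and came with bromo in place of hydrogen on an aromatic carbon. It is modest but beyond the scatter. For the measured compounds named here, no measured compound carries fluoro, so the data give no direct step for it. The working assumption is that fluoro lands closer to hydrogen than to bromo and so gives back most, though not all, of that gain. The expected move in this assay is therefore toward a lower number, and the estimated step is a 3.8-fold lower number from compound 2 to compound 3 (0.58 log units; beyond the scatter) in size, beyond the scatter. Compound 3 is expected at an estimated 25 10^-6 cm/s (range 10 10^-6 cm/s to 60 10^-6 cm/s).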

Compound 3, apparent permeability: 18.3 10^-6 cm/s
Beside the measured number, compound 3's estimate is 1.4-fold (0.14 log units) above it, and the stated range covers the measured number.
By their numbers in this assay, from the lowest: compounds 1 and 3 (each within the scatter of the next); then compound 2.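

Among these compounds, compound 3 gives the first comparison of two different groups at this aromatic carbon in this assay: changing bromo to fluoro gives a 5.2-fold lower number from compound 2 to compound 3 (0.72 log units; beyond the scatter), so the higher number seen with bromo does not carry over to fluoro, even though each group adds a single halogen atom. Against the hydrogen at the same place, fluoro gives a 1.3-fold higher number from compound 1 to compound 3 (0.13 log units; within the scatter), which means that these two compounds cannot be told apart on this read-out and that, of the three groups shown at this position, only bromo sets its compound apart. The data offer no measured explanation for why bromo and fluoro differ here.

The compounds shown leave open how chloro, iodo, a methoxy group or an amine would behave at this position, and therefore whether the higher number is special to bromo or is shared with other groups. They also leave open whether the same change from bromo to fluoro would produce a step of similar size at another place on the shared core.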